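A few compounds are considered here, and "the series" means these few. Any claim that something is new, unique, unknown or untested is made for them only; others in the source may bear on it.

Among the measured compounds shown here, in a functional assay on A549 cells (Homo sapiens) for cytotoxicity, read by MTT assay, with a stated time of 72 h (on this read-out lower numbers stand for stronger inhibition and higher numbers for weaker inhibition), compound 2 `CNC(=O)c1cc(Oc2ccc(C3=NN(C(N)=S)C(c4ccc(F)cc4)C3)cc2)ccn1` gives 19400 nM, the only exact number available so far. Compound 1 `CNC(=O)c1cc(Oc2ccc(C3=NN(C(N)=S)C(c4cccc([N+](=O)[O-])c4)C3)cc2)ccn1` gives > 50000 nM, which is a limit of the assay. For the measured compounds named here, the single measured step, an at least 2.5-fold lower number from compound 1 to compound 2 (0.41 log units; beyond the scatter), replaces 3-nitrophenyl with 4-fluorophenyl on a saturated ring carbon, and one end of it rests on the limit (the limit of > 50000 nM in this assay, at which 1 of the 2 values shown sits). Compound 3 `CNC(=O)c1cc(Oc2ccc(C3=NN(C(N)=S)C(c4ccc(Cl)cc4)C3)cc2)ccn1` differs from compound 2 by chloro in place of fluoro on an aromatic carbon, para to a large group: chloro in place of fluoro on an aromatic carbon. Going by the values given here, no measured step exchanges fluoro for chloro, so the evidence is indirect. Among the compounds with values here, the step to compound 2 shows only that changing this aryl group can shift the number. A modest shift at most is therefore expected in this assay, with no clear direction. The expected step is a 1.2-fold lower number from compound 2 to compound 3 (0.08 log units; within the scatter), which would not lie beyond the scatter. For compound 3 the estimated value is 16000 nM, with an expected range from 6000 nM to 42000 nM.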

Compound 3, half-maximal inhibitory concentration: > 50000 nM
Compound 3: no number, only a limit; the forecaster's own chance of this, stated with the estimate: 12%; middle value at least 3.1-fold (0.49 log units) from the limit.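

In this assay, the step of an at least 2.5-fold higher number from compound 2 to compound 3 (0.41 log units; beyond the scatter) shows that exchanging fluoro for chloro on this aromatic carbon, para to a large group, is enough by itself to move the number beyond the scatter. The earlier step replaced 3-nitrophenyl with 4-fluorophenyl, so it could not show the effect of a single atom exchanged at one unchanged place. Compound 2 is now the only one of the three with an exact number, and the other two stand at a limit of the assay: the limit of > 50000 nM in this assay, at which 2 of the 3 values shown sit.

On these data alone, the step from compound 1 to compound 3 cannot be read, and how far compound 3 lies past its limit stays open. As far as these compounds go, it also remains open whether a methoxy group or an amine at this place would give a number within the range of the assay.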